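This account rests on a few compounds, and the source may have more. Where it says the series, first, only, none or still open, it means among the compounds named here.

In an ADME assay on TZM cells (Homo sapiens) for cytotoxicity, read by XTT assay, with a stated time of 4 days (a lower number here means that less compound is tolerated, a higher number that more compound is tolerated), compound 1 `Cc1cc(CO)cc(C)c1Oc1cc(Nc2ccc(C#N)cc2)c(N)cc1CO` gives 15900 nM. Compound 2 `CC(=O)CCc1cc(C)c(Oc2cc(Nc3ccc(C#N)cc3)c(N)cc2C(F)(F)F)c(C)c1` gives 11100 nM, which lies within the scatter of compound 1, so the two numeric values in the set stand level. Compound 3 `Cc1cc(/C=C/C#N)cc(C)c1Oc1cc(Nc2ccc(C#N)cc2)c(N)cc1S(N)(=O)=O` returns only a limit, > 21800 nM.

The next compound is compound 4 `Cc1cc(CCC#N)cc(C)c1Oc1cc(Nc2ccc(C#N)cc2)c(N)cc1CO`, which keeps the core of compound 1 and changes one side chain: cyanomethyl in place of hydroxy on a saturated chain carbon bound to an aromatic carbon. Cyanomethyl stands in place of hydroxy on a saturated chain carbon bound to an aromatic carbon.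

For the measured compounds named here, no two measured compounds differ in only one place, so this change has no direct precedent in this assay. Even so, compound 2 at 11100 nM and compound 1 at 15900 nM differ in more than one place and remain within the scatter of each other. No step beyond the scatter is therefore expected, in either direction. The expected step is a 1.1-fold lower number from compound 1 to compound 4 (0.06 log units; within the scatter). Compound 4 is estimated at 14000 nM, with an expected range of 7000 nM to 28000 nM.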

Compound 4, half-maximal cytotoxic concentration: > 23800 nM
Compound 4: no number, only a limit (the forecaster's own chance of this, stated with the estimate: 25%); middle value at least 1.7-fold (0.23 log units) from the limit.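

In this assay, for the compounds shown here, cyanomethyl in place of hydroxy on a saturated chain carbon bound to an aromatic carbon, which reads one bond further out as hydroxymethyl to 2-cyanoethyl, gives the first single-place comparison: an at least 1.4-fold higher number from compound 1 to compound 4 (0.17 log units; that floor lies within the scatter). Going by these compounds alone, the floor of that step lies within the scatter, so the result shows only that this change at this place does not lower the number, while the real size of any rise remains unknown. Compound 4 returns a limit and not a number: the limit of > 23800 nM in this assay, at which 1 of the 4 values shown sits.

As far as these compounds go, how far the true value of compound 4 lies past that limit remains open, so the step cannot be sized. Also open, from the compounds shown here alone, is whether an amine, a carboxylic acid or a longer chain ending in a nitrile at this place would keep the number as high.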